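A Second Chloro Added to Two Related Cores

The compounds below may be only part of what the source reports. "The series", "measured", "known", "first", "only" and "open" are said of these compounds alone.

Compound 1 `ClCc1ccc(Cn2cnc3c(Cl)ncnc32)cc1` and compound 2 `ClCc1cccc(Cn2cnc3ncnc(Cl)c32)c1` are built from the same atoms joined differently; how the two cores differ is not broken down here. Compound 3 `ClCc1ccc(Cn2cnc3c(Cl)nc(Cl)nc32)cc1` is compound 1 with one change, (chloro in place of hydrogen on an aromatic carbon). Compound 4 `ClCc1cccc(Cn2cnc3nc(Cl)nc(Cl)c32)c1` has not yet been measured and is compound 2 with the same change, (chloro in place of hydrogen on an aromatic carbon), at a place described in the same words.

In a functional assay on MOLT-4 cells (Homo sapiens) for cytotoxicity, read by sulforhodamine B assay, with a stated time of 48 h (on this read-out higher numbers stand for weaker inhibition of growth and lower numbers for stronger inhibition of growth), compound 1 reaches only the limit of the method, > 100000 nM. Compound 3 gives 27500 nM, and compound 2 gives 29500 nM. The values of compound 2 and compound 3 lie close together. Among the measured compounds shown here, the one measured step, an at least 3.6-fold lower number from compound 1 to compound 3 (0.56 log units; beyond the scatter), can only be given as a lower bound because compound 1 sits at the limit of > 100000 nM in this assay, at which 1 of the 3 values shown sits.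

For compound 4 the same change is made on the other core, starting from compound 2, which already gives a number rather than a limit. For the measured compounds named here, the expectation is that the second chloro again lowers the number, though with only one measured example, and that one open-ended, the size of the step is uncertain. Compound 4 is estimated at 12000 nM, with a range from 4000 nM to 40000 nM. Going by the values given here, this estimate means an expected step of a 2.5-fold lower number from compound 2 to compound 4 (0.39 log units; beyond the scatter), resting on an at least 3.6-fold lower number from compound 1 to compound 3 (0.56 log units; beyond the scatter) as the only guide.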

Compound 4, concentration for total growth inhibition: 2290 nM
Compound 4: the middle estimate sits 5.2-fold (0.72 log units) above what was measured; the measured number lies below the stated range.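

In this assay, placing the chloro on the aromatic carbon between two ring nitrogen atoms gives a 13-fold lower number from compound 2 to compound 4 (1.11 log units; beyond the scatter), a large step. The number falls with this change on both cores, which shows that the direction of the step carried over in these two pairs, and two pairs are too few to make it a rule for the series: the same change on two cores in this assay, an at least 3.6-fold lower number (0.56 log units; beyond the scatter) from compound 1 to compound 3 and a 13-fold lower number (1.11 log units; beyond the scatter) from compound 2 to compound 4; the limit leaves it open whether they differ What the pairs do not show is whether the size of the step carries over as well, since the value of compound 1 is a limit and not a number: the limit of > 100000 nM in this assay, at which 1 of the 4 values shown sits.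

The compounds shown have only hydrogen or chloro at this place, and it remains open whether an amine, a methoxy group or a longer chain there would lower the number as well, or change it at all. All of these results also come from a single cell line, which leaves open whether the same step would appear in other cells, and whether compound 4 differs from compound 2 in anything other than growth inhibition.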